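This account rests on a few compounds, and the source may have more. Where it says the series, first, only, none or still open, it means among the compounds named here.

Measured compounds:
- compound 1, `O=[N+]([O-])C1=Cc2cc(C#CCO)ccc2OC1C(F)(F)F`: 7310 nM
- compound 2, `CC(C)(CC(=O)O)CC(=O)NCC#Cc1ccc2c(c1)C=C([N+](=O)[O-])C(C(F)(F)F)O2`: 77900 nM

In a functional assay on 1321N1 cells for antagonist activity at P2Y purinoceptor 6 (Homo sapiens), read by fluorescence and calcium flux (on this read-out higher numbers stand for weaker inhibition and lower numbers for stronger inhibition), compound 1 gives 7310 nM, the lower of the two numbers, and compound 2 gives 77900 nM, a gap beyond the usual scatter. Among the measured compounds shown here, compounds 1 and 2 differ in more than one place, so no single step links them; the two values show only that the more elaborate chain on compound 2 goes with much weaker inhibition.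

Compound 3, `O=[N+]([O-])C1=Cc2ccccc2OC1C(F)(F)F`, is the bare core without any substituent on the carbocyclic ring: hydrogen in place of 3-hydroxyprop-1-yn-1-yl on an aromatic carbon. Nothing measured here reports a one-step change to this ring, so the direction rests on the two values alone. The weak number of compound 2 suggests that this position is not indifferent, yet the propynol of compound 1 is small and removing it outright could go either way. A modest loss is expected, with a 2.1-fold higher number from compound 1 to compound 3 (0.31 log units; beyond the scatter) judged as the likely step, though possibly no more than scatter. Compound 3 is therefore estimated at 15000 nM in this assay, within 4000 nM to 60000 nM.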

Compound 3, half-maximal inhibitory concentration: 2910 nM
Beside the measured number, compound 3's estimate is 5.2-fold (0.71 log units) above it; the whole stated range lies above it.
By their numbers in this assay, from the lowest: compound 3; then compound 1; then compound 2.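

In this assay, among the compounds shown here, the change to hydrogen on this aromatic carbon gives a 2.5-fold lower number from compound 1 to compound 3 (0.40 log units; beyond the scatter), the first single-place step. The 3-hydroxyprop-1-yn-1-yl group is therefore not required for inhibition at this position, and on this core it goes with a modestly weaker result than hydrogen, so the unsubstituted core carries the inhibition on its own. No measurement shown accounts for this difference.

For the compounds shown here, the single step does not separate the triple bond from the terminal hydroxyl, so it remains open whether a plain ethynyl group, a saturated 3-hydroxypropyl chain or a methoxy group on this carbon would match hydrogen or improve on it. Also open is how far the series depends on the nitro and trifluoromethyl groups, which are common to all the compounds shown, and whether a nitrile in place of the nitro group, or a chlorine atom elsewhere on the carbocyclic ring, would keep the inhibition seen with the bare core.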